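Replacing 3,4-difluorophenyl in compound 2

A few compounds are considered here, and "the series" means these few. Any claim that something is new, unique, unknown or untested is made for them only; others in the source may bear on it.

Measured in an ADME assay on microsomes from liver (Mus musculus) for metabolic stability, read by LC-MS, using NADPH, with a stated time of 60 min, tested at 0.1 uM; on this read-out higher numbers stand for a more stable compound and lower numbers for a less stable compound:
compound 1 `Fc1ccc(Nc2cc3[nH]c(Nc4ccc(N5CCN(CC6CC6)CC5)cn4)nc3cn2)cc1C(F)(F)F`: 41%
compound 2 `Fc1ccc(Nc2cc3[nH]c(Nc4ccc(N5CCN(CC6CC6)CC5)cn4)nc3cn2)cc1F`: 14%
compound 3 `Fc1ccc(Nc2cc3[nH]c(Nc4ccc(C5CCNCC5)cn4)nc3cn2)cc1F`: 87%

Among these three, compound 2 stands lowest at 14%, and the other two lie beyond the scatter above it. Compound 4 `FC1(F)CC(Nc2cc3[nH]c(Nc4ccc(N5CCN(CC6CC6)CC5)cn4)nc3cn2)C1` has 3,3-difluorocyclobutyl in place of 3,4-difluorophenyl on a nitrogen on an aromatic ring. For the measured compounds named here, the only measured change within this aromatic group is a number 27 percentage points lower from compound 1 to compound 2 (beyond the scatter), a modest step beyond the scatter. The other measured step, a number 73 percentage points higher from compound 2 to compound 3 (beyond the scatter), is large, but it replaces 4-(cyclopropylmethyl)piperazin-1-yl, which compound 4 keeps, so it offers little guidance here. Going by the values given here, no measured compound carries a non-aromatic group on that nitrogen, so the direction remains uncertain. A modest rise in this assay is expected, comparable in size to the step from compound 1 to compound 2 and well short of the large one. The expected change is a number 12 percentage points higher from compound 2 to compound 4 (beyond the scatter). Compound 4 is estimated at 26%, with an expected range of 10% to 50%.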

Compound 4, percent of the compound remaining: 54%
For compound 4 the middle estimate is 28 percentage points below the measured one; the measured number lies above the stated range.
By their numbers in this assay, from the lowest: compound 2; then compound 1; then compound 4; then compound 3.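

In this assay, the group on this nitrogen need not be aromatic: 3,3-difluorocyclobutyl in place of 3,4-difluorophenyl gives a number 40 percentage points higher from compound 2 to compound 4 (beyond the scatter), a large step made with 4-(cyclopropylmethyl)piperazin-1-yl unchanged. For the compounds shown here, the same group also compares well with 4-fluoro-3-(trifluoromethyl)phenyl, with a number 13 percentage points higher from compound 1 to compound 4 (beyond the scatter), whereas the earlier compounds showed only a change of substituent on the aromatic ring at this position. Nothing at hand accounts for the rise with this change.

Going by these compounds, whether the rise goes with the four-membered ring or with its two fluorines stays open, and a plain cyclobutyl or a cyclohexyl group on this nitrogen would speak to that. On these data alone, it is also open whether 3,3-difluorocyclobutyl would act in the same way alongside piperidin-4-yl.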